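Lengthening the Chain Between Ring Nitrogen and Azepane

A few compounds are considered here, and "the series" means these few. Any claim that something is new, unique, unknown or untested is made for them only; others in the source may bear on it.

Three compounds that share a bicyclic core carrying a saturated chain ending in an azepane ring have been measured in an assay on cell membranes for displacement of a labelled ligand from Sigma non-opioid intracellular receptor 1 (Rattus norvegicus); a higher number here means a weaker inhibitor, a lower number a stronger inhibitor. Compound 1 `CCC(=O)c1ccc2c(c1)sc(=O)n2CCN1CCCCCC1` gives 4.5 nM. In this assay compound 2 `CCC(=O)c1ccc2c(c1)sc(=O)n2CCCN1CCCCCC1` gives 3.7 nM. The single counted difference between these two is (azepan-1-yl)methyl in place of azepan-1-yl on a saturated chain carbon, two bonds along the chain from an aromatic nitrogen, and the step that this change made was a 1.2-fold lower number from compound 1 to compound 2 (0.09 log units; within the scatter). Compound 3 `CCCc1ccc2c(c1)sc(=O)n2CCCCCN1CCCCCC1` gives 4.6 nM in this assay; how the core of compound 3 differs from the core of compound 1 is not broken down here, and the two values sit within the scatter of each other, as do all three measured numbers.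

Compound 4 `CCCc1ccc2c(c1)sc(=O)n2CCCCCCN1CCCCCC1` has not yet been measured in this assay. It differs from compound 3 by (azepan-1-yl)methyl in place of azepan-1-yl on a saturated chain carbon, five bonds along the chain from an aromatic nitrogen. Among the compounds with values here, this is the same kind of change as the one from compound 1 to compound 2, not the same change: in the earlier pair the place is two bonds along the chain from an aromatic nitrogen, while here it is five bonds along the chain from an aromatic nitrogen, and the cores of the two pairs differ as well.

Within the data shown here, the only measured instance of this kind of change gave a step of a 1.2-fold lower number from compound 1 to compound 2 (0.09 log units; within the scatter), which lies within the scatter, and nothing among the three compounds points to a larger effect at the longer chain. Compound 4 is therefore expected to give about 4.5 nM in this assay. The step this estimate implies, a 1.0-fold lower number from compound 3 to compound 4 (0.01 log units; within the scatter), is expected to stay within the scatter. Allowing for measurement spread, compound 4 is estimated to fall between 2 nM and 10 nM.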

Compound 4, inhibition constant: 6.3 nM
Compound 4: middle estimate off by 1.4-fold (0.15 log units), on the low side; low and high end bracket the measured number.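

In this assay, putting (azepan-1-yl)methyl in place of azepan-1-yl on a saturated chain carbon, five bonds along the chain from an aromatic nitrogen, gave a 1.4-fold higher number from compound 3 to compound 4 (0.14 log units; within the scatter). The two instances of this kind of change point in opposite directions, but that difference carries no weight, since the two steps cannot be told apart: the same change on two cores in this assay, a 1.2-fold lower number (0.09 log units; within the scatter) from compound 1 to compound 2 and a 1.4-fold higher number (0.14 log units; within the scatter) from compound 3 to compound 4, 1.7-fold (0.22 log units) apart, within the scatter of two such steps. So in both pairs this change left the number within the scatter on either core, but two small steps do not show that chain length is unimportant in general, and they cannot separate any influence of the core from that of the place along the chain, since both differ between the pairs.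

The compounds shown leave open whether a chain longer than that of compound 4, or a very short chain, would move the number beyond the scatter. They also leave open whether a different group at the chain end, such as a piperidine or morpholine ring in place of the azepane, would respond to chain length in the same way.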